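The compounds below may be only part of what the source reports. "The series", "measured", "known", "first", "only" and "open" are said of these compounds alone.

Compound 1, `O=[N+]([O-])c1ccc(C(F)F)cc1`: in a physicochemical assay for lipophilicity, read by spectrophotometry, using the shake flask method, measured as octanol-water partition (on this read-out higher numbers stand for higher lipophilicity and lower numbers for lower lipophilicity), compound 1 gives 2.12.
Compound 2, `Cc1ccc(C(F)F)cc1`: in this assay compound 2 gives 2.94.
Compound 3, `FC(F)OCCc1ccccc1`: in this assay compound 3 gives 3.16.

Compound 3 stands highest of the three numbers. Its nearest neighbour is compound 2, and that gap lies within the scatter, so no order between the two can be claimed; the gap to compound 1 is beyond the scatter. Going by the values given here, the only step between measured compounds that differ in one place is a number 0.82 log units higher from compound 1 to compound 2 (beyond the scatter), which covers methyl in place of nitro on an aromatic carbon.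

Compound 4, `FC(F)SCCc1ccccc1`, differs from compound 3 by (difluoromethyl)sulfanyl in place of difluoromethoxy on a saturated chain carbon, two bonds along the chain from an aromatic carbon. Among the compounds with values here, no measured step covers an exchange of oxygen for sulfur in such a chain, and the step from compound 1 to compound 2 is a different kind of change, so it gives no direct guide. The expectation therefore rests on the structural change alone, and a rise is expected rather than a fall. In this assay compound 4 is expected to give 3.7, with a range from 3.3 to 4.1. The expected step is a number 0.54 log units higher from compound 3 to compound 4 (beyond the scatter), modest and beyond the scatter.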

Compound 4, partition coefficient: 3.16
Compound 4: middle estimate off by 0.54 log units, on the high side; measured number outside the range, below it.
By their numbers in this assay, from the lowest: compound 1; then compounds 2, 3 and 4 (each within the scatter of the next).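

In this assay, (difluoromethyl)sulfanyl in place of difluoromethoxy on a saturated chain carbon, two bonds along the chain from an aromatic carbon, gives no change at the digits printed from compound 3 to compound 4 (within the scatter) at this position. Going by these compounds alone, this is the first measured exchange on the chain, since the earlier step, a number 0.82 log units higher from compound 1 to compound 2 (beyond the scatter), concerned an aromatic carbon and a different pair of groups. Here, swapping the oxygen link for a sulfur link leaves no measurable mark on the read-out, and nothing available explains that outcome.

As far as these compounds go, whether the same exchange would read the same way on a longer chain, or directly on an aromatic carbon, stays open. Also open, from the compounds shown here alone, is how an amine or a carboxylic acid in place of either group at this chain position would read in this assay.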